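A few compounds are considered here, and "the series" means these few. Any claim that something is new, unique, unknown or untested is made for them only; others in the source may bear on it.

Compound 1, `C=CCNC(=O)/C(C)=C(/C)c1ccc(Cl)cc1`, in a toxicity assay on the whole organism (strain Icem-CET (SPF Caw)) for cytotoxicity, with Mus musculus as the target (a higher number here means that more compound is needed for the effect, a lower number that less compound is needed), gives 280 mg/kg.
Compound 2, `C#CCNC(=O)/C(C)=C(\C)c1ccc(Cl)cc1`, in this assay gives 400 mg/kg.
Compound 3, `C=CCNC(=O)/C(C)=C(\C)c1ccc(C)cc1`, in this assay gives 170 mg/kg.

Among these three, compound 3 stands closest to compound 1, the two lying within the usual scatter of repeated measurements of each other, and furthest from compound 2, whose higher number lies beyond that scatter. Compound 4, `C=CCNC(=O)/C(C)=C(\C)c1ccc(Cl)cc1`, has not yet been measured in this assay. It differs from compound 3 in one place: chloro in place of methyl on an aromatic carbon. Going by the values given here, no measured pair shows this single change on its own, so the step is expected to be small, estimated as a 1.4-fold higher number from compound 3 to compound 4 (0.13 log units; within the scatter), toward a higher number but not beyond the scatter. Compound 4 is therefore expected to give about 230 mg/kg, within a range from 110 mg/kg to 480 mg/kg.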

Compound 4, dose for half-maximal effect: 90 mg/kg
The estimate for compound 4 lay 2.6-fold (0.41 log units) above the measured number; measured number below the stated range.
By their numbers in this assay, from the lowest: compounds 4, 3, 1 and 2 (each within the scatter of the next, the first and the last beyond it).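

In this assay, chloro in place of methyl on the aromatic carbon gives a 1.9-fold lower number from compound 3 to compound 4 (0.28 log units; within the scatter), so this change does not separate the two groups at this position. The end of the nitrogen chain does register, vinyl in place of ethynyl giving a 4.4-fold lower number from compound 2 to compound 4 (0.65 log units; beyond the scatter). The double-bond geometry registers too, and a 3.1-fold lower number from compound 1 to compound 4 (0.49 log units; beyond the scatter) has a single possible source: the fact that compounds 1 and 4 differ only in the configuration as drawn.

Open, on these data alone, is whether a methoxy group or a carboxylic acid at this ring position would give a step beyond the scatter, and what a longer chain on the amide nitrogen would do.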